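Adding a Chloro Substituent to the Urea Aryl Ring

The source may hold more compounds than are shown below. What is called first, only, known or untested is meant among the compounds shown, and "the series" means these compounds.

Compound 2 `COc1cc(-c2nn(-c3cccc(NC(=O)Nc4cccc(C(F)(F)F)c4)c3)cc2-c2ccncc2)ccc1Cl` carries a 3-(trifluoromethyl)phenyl urea, and in a functional assay on PC-3 cells (Homo sapiens) for inhibition, read by sulforhodamine B assay, with a stated time of 48 h (on this read-out lower numbers stand for stronger inhibition and higher numbers for weaker inhibition), compound 2 gives 370 nM. Among the two measured compounds this is the higher number; its nearest neighbour is compound 1 `COc1cc(-c2nn(-c3cccc(NC(=O)Nc4cc(C(F)(F)F)cc(C(F)(F)F)c4)c3)cc2-c2ccncc2)ccc1Cl`, which in this assay gives 250 nM, and the step of a 1.5-fold higher number from compound 1 to compound 2 (0.17 log units; within the scatter) shows how little the loss of one trifluoromethyl group mattered. Compound 3 `COc1cc(-c2nn(-c3cccc(NC(=O)Nc4ccc(Cl)c(C(F)(F)F)c4)c3)cc2-c2ccncc2)ccc1Cl` is not yet measured and differs from compound 2 in one place: chloro in place of hydrogen on an aromatic carbon. Within the data shown here, the only measured step that bears on this position is the change from compound 1 to compound 2, in which a group was removed from the same ring and the number stayed within the scatter. Adding a single chloro back onto that ring is therefore expected to move the number little, if anything slightly downward. For compound 3 the estimate in this assay is 250 nM, with a range from 100 nM to 600 nM. The step from compound 2 is expected to be a 1.5-fold lower number from compound 2 to compound 3 (0.17 log units; within the scatter).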

Compound 3, half-maximal inhibitory concentration: 690 nM
Beside the measured number, compound 3's estimate is 2.8-fold (0.44 log units) below it; measured number above the stated range.
By their numbers in this assay, from the lowest: compounds 1, 2 and 3 (each within the scatter of the next, the first and the last beyond it).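

In this assay, the chloro group on compound 3 sits at a place on the urea aryl ring that the earlier step did not touch: ortho to a trifluoromethyl group and para to a large group. The step reads a 1.9-fold higher number from compound 2 to compound 3 (0.27 log units; within the scatter), so compound 2 and compound 3 cannot be told apart in this assay, and this position carries a chloro group with no difference that stands clear of the scatter. Only one change at this place is shown, and no information on cell uptake, target engagement or any other measured property bears on this step.

The compounds shown leave open whether a different group at this position, such as a fluoro, a methoxy, an amine or a carboxylic acid, would stay within the scatter of compound 2 as the chloro group does. They also leave open whether the chloro group would read the same on a ring without the trifluoromethyl group, or on a urea aryl ring that keeps both trifluoromethyl groups of compound 1.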